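Swapping the furan of compound 1 for a thiophene

This account rests on a few compounds, and the source may have more. Where it says the series, first, only, none or still open, it means among the compounds named here.

Compound 1 `Cc1ccc(-c2nc(N)c3nn(-c4ccccc4O)cc3n2)o1` gives 375 nM in an assay on CHO cells for displacement of a labelled ligand from adenosine receptor A3 (Homo sapiens), read by scintillation counting, with a stated time of 60 min (on this read-out higher numbers stand for weaker inhibition and lower numbers for stronger inhibition), the higher of the two numbers in hand. For the measured compounds named here, compound 2 `Cc1ccc(-c2nc(N)c3nn(-c4ccccc4)cc3n2)o1` gives 147 nM in this assay, and the single measured step, a 2.6-fold lower number from compound 1 to compound 2 (0.41 log units; beyond the scatter), concerns a different position. Compound 3 `Nc1nc(-c2cccs2)nc2cn(-c3ccccc3O)nc12` differs from compound 1 by thiophen-2-yl in place of 5-methylfuran-2-yl on an aromatic carbon. Going by the values given here, no measured step touches this exchange, so the one known step offers no guide to its size. The expected step is therefore no change at the digits printed from compound 1 to compound 3 (within the scatter), none beyond the scatter. Compound 3 is estimated at 375 nM, within a range of 120 nM to 1200 nM.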

Compound 3, inhibition constant: 209 nM
Compound 3: the middle estimate sits 1.8-fold (0.25 log units) above what was measured; measured number inside the range.
By their numbers in this assay, from the lowest: compounds 2, 3 and 1 (each within the scatter of the next, the first and the last beyond it).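

In this assay, thiophen-2-yl in place of 5-methylfuran-2-yl gives a 1.8-fold lower number from compound 1 to compound 3 (0.25 log units; within the scatter) and so stays within the scatter. For the compounds shown here, this is the first reading at this position, and with the hydroxy group kept, the two five-membered aromatic rings are not told apart here. Nothing measured gives a reason for this result.

As far as these compounds go, what furan-2-yl without its methyl, or a phenyl ring, would give at this position remains open. Also open, from the compounds shown here alone, is whether the exchange reads the same on compound 2, which has hydrogen in place of hydroxy.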